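Swapping a chlorinated benzyl for a methylated one

The compounds below may be only part of what the source reports. "The series", "measured", "known", "first", "only" and "open" are said of these compounds alone.

Three compounds have been measured in a functional assay on RAW264.7 cells (Mus musculus) for inhibition, read by Griess assay, with stated times of 2 h and 24 h; on this read-out lower numbers stand for stronger inhibition and higher numbers for weaker inhibition:

compound 1 `COc1ccc([C@@H]2CC(=O)c3c(O)cc(OCc4cn(Cc5cccc(Cl)c5)nn4)cc3O2)cc1O`: 18200 nM
compound 2 `COc1ccc([C@@H]2CC(=O)c3c(O)cc(OCc4cn(Cc5ccccc5C#N)nn4)cc3O2)cc1O`: 14600 nM
compound 3 `COc1ccc([C@@H]2CC(=O)c3c(O)cc(OCc4cn(Cc5ccccc5Cl)nn4)cc3O2)cc1O`: 6140 nM

Compound 3 has the lowest number of the three, and both of its steps from the others lie beyond the scatter: a 3.0-fold lower number from compound 1 to compound 3 (0.47 log units; beyond the scatter) and a 2.4-fold lower number from compound 2 to compound 3 (0.38 log units; beyond the scatter). The step from compound 1 to compound 2, a 1.2-fold lower number from compound 1 to compound 2 (0.10 log units; within the scatter), stays within the scatter.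

Compound 4 `COc1ccc([C@@H]2CC(=O)c3c(O)cc(OCc4cn(Cc5ccc(C)cc5)nn4)cc3O2)cc1O` differs from compound 3 in one place: 4-methylphenyl in place of 2-chlorophenyl on a saturated chain carbon bound to an aromatic nitrogen. Among the compounds with values here, no measured step covers a methyl group at all, so the guidance is indirect. The step from compound 1 to compound 3 shows that moving the chlorine from 3-chlorophenyl to 2-chlorophenyl lowered the number modestly; compound 4 gives up the 2-chlorophenyl entirely. The expectation is therefore that the number rises back toward the range of compound 1 and compound 2, with a 2.0-fold higher number from compound 3 to compound 4 (0.29 log units; within the scatter) as the estimated step. For compound 4 the estimated value in this assay is 12000 nM, within a range of 5000 nM to 30000 nM.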

Compound 4, half-maximal inhibitory concentration: 16800 nM
For compound 4 the middle estimate is 1.4-fold (0.15 log units) below the measured one; measured number inside the range.
By their numbers in this assay, from the lowest: compound 3; then compounds 2, 4 and 1 (each within the scatter of the next).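

Putting 4-methylphenyl in place of 2-chlorophenyl on this saturated chain carbon gives a 2.7-fold higher number from compound 3 to compound 4 (0.44 log units; beyond the scatter) in this assay and shows that a benzyl group with a methyl and no chlorine does not keep the low number of compound 3. Compound 4 cannot be separated from the other two, with a 1.2-fold higher number from compound 2 to compound 4 (0.06 log units; within the scatter) and a 1.1-fold lower number from compound 1 to compound 4 (0.03 log units; within the scatter) both within the scatter, so only 2-chlorophenyl stands apart among these four groups, and 2-cyanophenyl in compound 2 shows that filling the same ring position does not by itself match it. Nothing measured here explains why compound 3 stands apart.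

Still open, on these data alone, is whether the low number depends on the chlorine itself or on where it sits, which 4-chlorophenyl or 2-methylphenyl could help separate. As far as these compounds go, how an amine or a carboxylic acid on the ring would behave at this place also remains unknown.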